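This account rests on a few compounds, and the source may have more. Where it says the series, first, only, none or still open, it means among the compounds named here.

In a physicochemical assay for pharmacokinetics, at pH 4 (on this read-out lower numbers stand for a shorter-lived compound and higher numbers for a longer-lived compound), three compounds have been measured so far, and each returned a limit of the assay rather than a number. Compound 1 `COc1ccc(C(=O)NCc2ccncc2)cc1` gives > 1000 h, a limit. Compound 2 `COc1cccc(CNC(=O)c2ccc(Oc3ccc(C)cc3)cc2)c1` gives > 1000 h, again a limit. Compound 3 `O=C(NCc1ccncn1)c1ccc(Oc2ccc(/C=C/C3=CN4CCC3CC4)cc2)cc1` gives > 1000 h, also a limit. Compound 2 therefore stands at the reporting edge of this assay, as the limit of > 1000 h in this assay, at which 3 of the 3 values shown sit, shows. Compound 4 `CNC(=O)c1ccc(Oc2ccc(C)cc2)cc1` differs from compound 2 in one place: hydrogen in place of 3-methoxyphenyl on a saturated chain carbon bound to an amide-type nitrogen. Among the measured compounds shown here, no step between two measured compounds has been recorded in this assay, so no measured change in half-life attaches to any structural move. The expected step that the limit leaves unreadable from compound 2 to compound 4 is none beyond the scatter. Compound 4 is estimated at 1500 h, between 1000 h and 5000 h, most likely again a limit.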

Compound 4, half-life: > 1000 h
Compound 4: no number, only a limit; the forecaster's own chance of this, stated with the estimate: 90%; the middle value does not contradict the limit.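

Compound 2 and compound 4 each return a limit rather than a number, so the step between them cannot be read. The compounds shown leave open how long any of them actually lasts in this assay.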